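A few compounds are considered here, and "the series" means these few. Any claim that something is new, unique, unknown or untested is made for them only; others in the source may bear on it.

The measured compounds and their values:
compound 1 `COc1cc2c(cc1OC)C(CC(=O)O)CC2`, 24%
compound 2 `COc1cc2c(cc1OC)C(CC(N)=O)CC2`, 31%
compound 3 `CCN(CC)C(=O)CC1CCc2cc(OC)c(OC)cc21`, 40%

In a functional assay on the whole organism (strain Wistar) for inhibition, with Rattus norvegicus as the target, read by paw edema, with stated times of 60 min and 2 h, at a dose of 100 mg/kg by the oral route (a lower number here means less inhibition, a higher number more inhibition at the dose given (going by the name of the read-out)), compound 3 gives 40%, the highest of the three numbers shown. One of its steps lies within the scatter: a number 9 percentage points higher from compound 2 to compound 3 (within the scatter). The other stands beyond it: a number 16 percentage points higher from compound 1 to compound 3 (beyond the scatter). Compound 4 `COc1cc2c(cc1OC)C(CC(=O)NC1CCCC1)CC2` has not yet been measured. It differs from compound 3 in one place: cyclopentylamino in place of diethylamino on a carbonyl carbon. All three measured steps change the group on the same carbonyl carbon, so all of them bear on this one. Two lie within the scatter, a number 7 percentage points higher from compound 1 to compound 2 (within the scatter) and a number 9 percentage points higher from compound 2 to compound 3 (within the scatter), and one, a number 16 percentage points higher from compound 1 to compound 3 (beyond the scatter), is modest but beyond it. Exchanging one group on that carbonyl carbon for another has thus moved this assay little. For compound 4 a similar outcome is expected, with no step beyond the scatter: a number 2 percentage points lower from compound 3 to compound 4 (within the scatter). Compound 4 is therefore estimated at 38%, with a range from 24% to 52%.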

Compound 4, a percentage reported as inhibition, in the whole organism at one dose (the size of the read-out at that dose, not a potency): 52%
Compound 4: middle estimate off by 14 percentage points, on the low side; the measured number falls inside the stated range.
By their numbers in this assay, from the lowest: compounds 1, 2 and 3 (each within the scatter of the next, the first and the last beyond it); then compound 4.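

In this assay, the carbonyl carbon now shows a step beyond the scatter between two amides, a number 12 percentage points higher from compound 3 to compound 4 (beyond the scatter), with cyclopentylamino in place of diethylamino. Among the earlier compounds, only the change from hydroxy to diethylamino had cleared the scatter. Cyclopentyl in place of hydrogen on the amide-type nitrogen gives a number 21 percentage points higher from compound 2 to compound 4 (beyond the scatter) as well, and cyclopentylamino in place of hydroxy gives a number 28 percentage points higher from compound 1 to compound 4 (beyond the scatter), so this position can move the read-out more than the earlier steps suggested. No measurement shown offers an explanation for these steps.

Compound 4 differs from compound 3 by both a ring and an amide hydrogen, so the two remain unseparated. An open-chain isopropylamino, which keeps the amide hydrogen, or a pyrrolidine amide, which keeps a ring without it, would pull them apart.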